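Trifluoromethyl for Methyl on a Shared Core

The source may hold more compounds than are shown below. What is called first, only, known or untested is meant among the compounds shown, and "the series" means these compounds.

Of the compounds shown here, two on one shared core have been measured in an ADME assay on microsomes from liver (Homo sapiens), read by LC-MS, with a stated time of 90 min; a lower number here means that the liver removes a smaller share, a higher number that the liver removes a larger share of the compound in one pass. Compound 1, `CC[C@H](C)n1c(=O)[nH]c2ncc(Br)nc21`, gives only a limit of the assay, < 0.2. Compound 2, `CCC(CC)n1c(=O)[nH]c2ncc(C)nc21`, likewise gives only a limit in this assay, < 0.2. Among the compounds with values here, both results sit at the same edge of measurement, (the limit of < 0.2 in this assay, at which 2 of the 2 values shown sit), so no step between measured compounds can be described, and compound 2 stands at that limit rather than at a number. Compound 3, `CCC(CC)n1c(=O)[nH]c2ncc(C(F)(F)F)nc21`, is not yet measured in this assay. It differs from compound 2 in one place: trifluoromethyl in place of methyl on an aromatic carbon. Within the data shown here, with no measured step to lean on, the change from compound 2 to compound 3 is expected to stay within the usual scatter. a step that the limit leaves unreadable from compound 2 to compound 3 is the step the estimate assumes, and it is expected to be small. Compound 3 is expected to give 0.1 in this assay, with a likely range from 0.02 to 0.25, and the result may well again be only a limit.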

Compound 3, hepatic extraction ratio: < 0.2
Compound 3: no number, only a limit; the forecaster's own chance of this, stated with the estimate: 65%; the middle value is on the limit's open side.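

Compound 2 and compound 3 each give only a limit in this assay, so no step between them can be read: the limit of < 0.2 in this assay, at which 3 of the 3 values shown sit.

The compounds shown leave open what actual number each would give, and so whether trifluoromethyl in place of methyl shifts this read-out at all.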